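From dibutylamino to dipentylamino on a shared core

The compounds below may be only part of what the source reports. "The series", "measured", "known", "first", "only" and "open" are said of these compounds alone.

Compounds tested in a functional assay on LNCaP cells (Homo sapiens) for antiproliferative activity, read by WST assay, with a stated time of 3 days; a higher number here means a weaker inhibitor, a lower number a stronger inhibitor:
compound 1 `CCCOc1c(-c2cc(OC)c(OC)c(OC)c2)oc2ccccc2c1=O`: 5700 nM
compound 2 `CCCN(CCC)CCCOc1c(-c2cc(OC)c(OC)c(OC)c2)oc2ccccc2c1=O`: 17900 nM
compound 3 `CCCCN(CCCC)CCCOc1c(-c2cc(OC)c(OC)c(OC)c2)oc2ccccc2c1=O`: 9000 nM

Compound 3 sits in the middle of these three numbers, and its value lies within the usual scatter of both compound 1 and compound 2. The next compound, compound 4 `CCCCCN(CCCCC)CCCOc1c(-c2cc(OC)c(OC)c(OC)c2)oc2ccccc2c1=O`, carries dipentylamino in place of dibutylamino on the same chain: dipentylamino in place of dibutylamino on a saturated chain carbon, three bonds along the chain from an oxygen on an aromatic ring.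

The closest evidence is the exchange of dipropylamino for dibutylamino, which gave a 2.0-fold lower number from compound 2 to compound 3 (0.30 log units; within the scatter). Replacing hydrogen with the amino groups gave a 3.1-fold higher number from compound 1 to compound 2 (0.50 log units; beyond the scatter) and a 1.6-fold higher number from compound 1 to compound 3 (0.20 log units; within the scatter). That leaves a single step of this chain-lengthening kind, and it did not clear the scatter, so no step beyond the scatter is expected in this assay. The expected step is a 1.1-fold lower number from compound 3 to compound 4 (0.05 log units; within the scatter). For compound 4 the estimated value is 8000 nM, with an expected range from 3500 nM to 18000 nM.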

Compound 4, half-maximal inhibitory concentration: 5100 nM
Compound 4: the middle estimate sits 1.6-fold (0.20 log units) above what was measured; measured number inside the range.
By their numbers in this assay, from the lowest: compounds 4, 1, 3 and 2 (each within the scatter of the next, the first and the last beyond it).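

In this assay, dipentylamino in place of dipropylamino gave the first exchange among these amino groups to clear the scatter (a 3.5-fold lower number from compound 2 to compound 4 (0.55 log units; beyond the scatter)), while dipentylamino in place of dibutylamino did not (a 1.8-fold lower number from compound 3 to compound 4 (0.25 log units; within the scatter)). Dipentylamino in place of hydrogen on the same chain stayed within the scatter (a 1.1-fold lower number from compound 1 to compound 4 (0.05 log units; within the scatter)), as dibutylamino had, so among the amino groups shown only dipropylamino stands beyond the scatter of the compound without one. Nothing available here explains these differences.

The compounds shown leave open whether a longer chain on the nitrogen, such as dihexylamino, would stay within the scatter of compound 4. They also leave open how a ring amine such as piperidine, or a smaller amine such as dimethylamino, would behave at this position.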